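A few compounds are considered here, and "the series" means these few. Any claim that something is new, unique, unknown or untested is made for them only; others in the source may bear on it.

Compound 1 `Nc1cc(C(F)(F)F)cc2c(=O)cc(N3CCN(CC4CCCCC4)CC3)sc12` carries an amino group on its shared core and stays largely intact: in an ADME assay on cells (Hepatocyte, Mus musculus) for metabolic stability, with a stated time of 30 min (on this read-out lower numbers stand for a less stable compound and higher numbers for a more stable compound), compound 1 gives 69.4%. Among the compounds with values here, compound 2 `O=C(OC1CCC(CN2CCN(c3cc(=O)c4cc(C(F)(F)F)cc([N+](=O)[O-])c4s3)CC2)CC1)C1CCCCC1` has a nitro group in place of that amino group and a cyclohexylcarbonyl ester on the cyclohexyl ring at the far end; in this assay compound 2 gives 1.2%, the lowest of the three numbers so far. Compound 3 `O=C(OC1CCC(CN2CCN(c3cc(=O)c4cc(C(F)(F)F)cc([N+](=O)[O-])c4s3)CC2)CC1)c1ccc(F)cc1` differs from compound 2 only at the ester, where 4-fluorophenyl replaces cyclohexyl on the carbonyl carbon; compound 3 gives 1.5%, and the step of a number 0.3 percentage points higher from compound 2 to compound 3 (within the scatter) stays within the scatter of repeated measurements.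

Compound 4 `O=C(OC1CCC(CN2CCN(c3cc(=O)c4cc(C(F)(F)F)cc([N+](=O)[O-])c4s3)CC2)CC1)c1cccs1` is the next variation at the same place: thiophen-2-yl in place of cyclohexyl on a carbonyl carbon. Within the data shown here, the only step that bears on this change is the one from compound 2 to compound 3, where a different ring on the same carbonyl carbon moved the number by an amount no larger than the usual scatter. Both ester compounds remain far below compound 1. On that basis the change to compound 4 is expected to leave the number essentially where compound 2 stands, with the step of a number 0.3 percentage points higher from compound 2 to compound 4 (within the scatter) expected to fall within the scatter. For compound 4 the estimate is 1.5%, with a range from 0.3% to 6%.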

Compound 4, percent of the compound remaining: 1.8%
For compound 4 the middle estimate is 0.3 percentage points below the measured one; low and high end bracket the measured number.
By their numbers in this assay, from the lowest: compounds 2, 3 and 4 (each within the scatter of the next); then compound 1.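

The comparison in this assay gives a number 0.6 percentage points higher from compound 2 to compound 4 (within the scatter) and also a number 0.3 percentage points higher from compound 3 to compound 4 (within the scatter) when thiophen-2-yl takes the place of 4-fluorophenyl. Compound 3 had already shown that one aromatic ring could take the place of cyclohexyl on this carbonyl carbon without a step beyond the scatter, and compound 4 extends that reading to a five-membered aromatic ring with a sulfur atom, so compounds 2, 3 and 4 cannot be told apart here. Nothing available explains why these three numbers sit so close together.

All three compounds keep the ester and the nitro group, and compound 1 differs from them in more than one place, so the shown compounds cannot say whether the low numbers belong to the ester, to the nitro group or to both. On these data alone, it also remains open whether an amine on the carbonyl carbon, making an amide, or a longer open carbon chain in place of the ring would leave the number just as it stands.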